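The compounds below may be only part of what the source reports. "The series", "measured", "known", "first", "only" and "open" are said of these compounds alone.

Compounds measured so far:
- compound 1, `CC1=NNC(=O)C1C(c1c(-c2ccccc2)[nH]c2ccc(C)cc12)c1c(-c2ccccc2)[nH]c2ccc(C)cc12`: > 100000 nM
- compound 2, `CC1=NNC(=O)C1C(c1c(-c2ccccc2)[nH]c2ccccc12)c1c(-c2ccccc2)[nH]c2ccc(Cl)cc12`: 41700 nM
- compound 3, `CC1=NNC(=O)C1C(c1c[nH]c2ccccc12)c1c(-c2ccccc2)[nH]c2ccc(Cl)cc12`: > 100000 nM

In a functional assay on HEp-2 cells (Homo sapiens) for cytotoxicity, read by MTT assay (on this read-out higher numbers stand for weaker inhibition and lower numbers for stronger inhibition), compound 2 gives 41700 nM. For compound 1 the reading of > 100000 nM is a limit of the assay and not a number. Compound 3 likewise sits at the limit, > 100000 nM. The only single-place step among these compounds, an at least 2.3-fold higher number from compound 2 to compound 3 (0.37 log units; beyond the scatter), is therefore open-ended, and compound 3 stands at the limit of > 100000 nM in this assay, at which 2 of the 3 values shown sit, together with compound 1, with compound 2 the one compound that returned a number.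

Compound 4, `CC1=NNC(=O)C1C(c1c[nH]c2ccccc12)c1c(-c2ccccc2)[nH]c2ccccc12`, is obtained from compound 3 by hydrogen in place of chloro on an aromatic carbon. Going by the values given here, no measured step in this set removes a chloro group alone; compound 1 and compound 2 differ in more than one place, and their values show only that compound 1 sits at the limit while compound 2 gives a number. With compound 3 already at the limit, the step from compound 3 to compound 4 is expected to be no larger than the scatter, a step that the limit leaves unreadable from compound 3 to compound 4, and most probably to end again at the limit. Compound 4 is accordingly estimated at 150000 nM in this assay, within a range of 60000 nM to 400000 nM, with the reading expected to be a limit rather than a number.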

Compound 4, half-maximal inhibitory concentration: 6700 nM
The estimate for compound 4 lay 22-fold (1.35 log units) above the measured number; the whole stated range lies above it.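

In this assay, hydrogen in place of chloro on an aromatic carbon gives an at least 14-fold lower number from compound 3 to compound 4 (1.17 log units; beyond the scatter), a large step that brings the reading off the limit and shows that this position, meta to a fused ring and para to a fused ring, is not indifferent to what it carries. The earlier compounds shown here could not show this, as no step among them changed this position alone, and compound 1 and compound 2 differ in more than one place. Compound 3 reads > 100000 nM, which is a limit of the assay and not a number, so the step gives only a lower bound on the change, and the same limit recurs in this set: the limit of > 100000 nM in this assay, at which 2 of the 4 values shown sit.

The compounds shown leave open whether removing chloro has a similar effect when the second phenyl group of compound 2 is kept, as no compound here has that phenyl group without the chloro group. They also leave open how other groups at this position, such as fluoro, methoxy or an amine, would compare with hydrogen and chloro.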